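Swapping Benzoyl on Two Cores: Estimating Compound 4

The source may report more compounds than this note shows. Statements on the series, on what has been measured and on what is new or still open speak of the compounds shown alone.

Compound 1 `C=CCn1c(SC/C(=N/O)c2ccccc2)nnc1-c1ccc(OC)cc1`: 67%
Compound 2 `C=CCn1c(SCC(=O)c2ccccc2)nnc1-c1ccc(OC)cc1`: 63%
Compound 3 `CCn1c(SCC(=O)c2ccccc2)nnc1-c1cc(OC)c(OC)c(OC)c1`: 49%

The three compounds were measured in a functional assay on the whole organism (strain albino) for inhibition, with Rattus norvegicus as the target, read by paw edema, with a stated time of 3 h, at a dose of 0.28 mmol/kg by the oral route; on this read-out lower numbers stand for less inhibition and higher numbers for more inhibition at the one dose given (going by the name of the read-out). Compound 2 and compound 1 share one core and differ only by the change (a group of 9 heavy atoms (7 carbon, 1 nitrogen, 1 oxygen; one six-membered aromatic ring of carbon only) in place of a group of 8 heavy atoms (7 carbon, 1 oxygen; one six-membered aromatic ring of carbon only), on a saturated chain carbon bound to a sulfur). That change gave the step of a number 4 percentage points higher from compound 2 to compound 1 (within the scatter), so the two numbers cannot be ordered against each other.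

Compound 3 carries a different core, and the difference between the two cores is not broken down here. In this assay compound 3 gives 49%, the lowest of the three numbers, and its distance from compound 2 lies beyond the scatter.

Compound 4 `CCn1c(SC/C(=N/O)c2ccccc2)nnc1-c1cc(OC)c(OC)c(OC)c1` is not yet measured. It stands to compound 3 as compound 1 stands to compound 2, through the change (a group of 9 heavy atoms (7 carbon, 1 nitrogen, 1 oxygen; one six-membered aromatic ring of carbon only) in place of a group of 8 heavy atoms (7 carbon, 1 oxygen; one six-membered aromatic ring of carbon only), on a saturated chain carbon bound to a sulfur), the same change at the same place. Going by the values given here, the only guide is the single earlier step, which was within the scatter, so a step of about a number 4 percentage points higher from compound 3 to compound 4 (within the scatter) is expected, resting on a number 4 percentage points higher from compound 2 to compound 1 (within the scatter). On that basis compound 4 is estimated at 53%, with a plausible range from 40% to 66%.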

Compound 4, a percentage reported as inhibition, in the whole organism at one dose (the size of the read-out at that dose, not a potency): 69%
For compound 4 the middle estimate is 16 percentage points below the measured one; measured number above the stated range.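

In this assay, replacing benzoyl on a saturated chain carbon bound to a sulfur did not give the same result on the two cores: the same change on two cores in this assay, a number 4 percentage points higher (within the scatter) from compound 2 to compound 1 and a number 20 percentage points higher (beyond the scatter) from compound 3 to compound 4, 16 percentage points apart, beyond the scatter of two such steps

On the core of compound 3, the swap gives a number 20 percentage points higher from compound 3 to compound 4 (beyond the scatter), so the size of the step seen on the core of compound 1 did not carry over to this second core. This does not show which part of the core goes with the larger step, as the two cores are not broken down into single changes, and two cores are too few to predict the step on a third.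

The compounds shown leave open how an amine or a carboxylic acid would read in place of benzoyl at this same chain carbon, on either core. They also leave open whether the two steps would stay apart at another oral dose or at another time after dosing.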